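One Aryl Swap, Measured Once, Expected Again

A few compounds are considered here, and "the series" means these few. Any claim that something is new, unique, unknown or untested is made for them only; others in the source may bear on it.

Compound 1 `C=C(C)C(=O)c1ccc(OCc2nc(-c3ccc4ccccc4c3)cs2)c(C)c1C` and compound 2 `C=C(C)C(=O)c1ccc(OCc2nc(-c3ccc(C(F)(F)F)cc3)cs2)c(C)c1C` share one core, while compound 3 `C=C(CC)C(=O)c1ccc(OCc2nc(-c3ccc4ccccc4c3)cs2)cc1Cl` and the not yet measured compound 4 `C=C(CC)C(=O)c1ccc(OCc2nc(-c3ccc(C(F)(F)F)cc3)cs2)cc1Cl` share another. In a functional assay on HL-60 cells (Homo sapiens) for inhibition, read by trypan blue exclusion, with a stated time of 72 h (a higher number here means a weaker inhibitor of growth, a lower number a stronger inhibitor of growth), compound 1 gives 2300 nM, and compound 2 gives 3100 nM. The step between them, a 1.3-fold higher number from compound 1 to compound 2 (0.13 log units; within the scatter), comes from 4-(trifluoromethyl)phenyl in place of naphthalen-2-yl on an aromatic carbon. In this assay compound 3 gives 900 nM, the lowest of the three numbers; how its core differs from the core of compound 1 is not broken down here. Compound 4 differs from compound 3 by 4-(trifluoromethyl)phenyl in place of naphthalen-2-yl on an aromatic carbon, the same change that separates compound 1 from compound 2. Because that change produced a 1.3-fold higher number from compound 1 to compound 2 (0.13 log units; within the scatter), the expected step is a 1.3-fold higher number from compound 3 to compound 4 (0.12 log units; within the scatter). Compound 4 is thus estimated at 1200 nM, with a likely range from 600 nM to 2400 nM.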

Compound 4, concentration for 50% growth inhibition: 2000 nM
For compound 4 the middle estimate is 1.7-fold (0.22 log units) below the measured one; measured number inside the range.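

In this assay, 4-(trifluoromethyl)phenyl in place of naphthalen-2-yl gives a 2.2-fold higher number from compound 3 to compound 4 (0.35 log units; beyond the scatter) on the second core, and the steps on the two cores do not clearly differ:
the same change on two cores in this assay, a 1.3-fold higher number (0.13 log units; within the scatter) from compound 1 to compound 2 and a 2.2-fold higher number (0.35 log units; beyond the scatter) from compound 3 to compound 4, 1.6-fold (0.22 log units) apart, within the scatter of two such steps

So the step measured on one core was a fair guide to the step on the other, although only the step on the core of compound 3 lies beyond the scatter on its own. Two cores are a small sample, and they do not show that the change would carry to any further core, or why it acts as it does.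

Open, going by these compounds, is how a plain phenyl, or a phenyl carrying an amine or a carboxylic acid, would compare at this place on either core.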